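The compounds below may be only part of what the source reports. "The series", "measured", "known", "first", "only" and "open" are said of these compounds alone.

In a functional assay on MDA-MB-435 cells (Homo sapiens) for antiproliferative activity (on this read-out higher numbers stand for weaker inhibition of growth and lower numbers for stronger inhibition of growth), compound 1 `Cc1cccc(-c2cc(O)c3ccc(C)nc3n2)c1` gives 32.4 nM, compound 2 `Cc1cc(C)c2c(O)cc(-c3cccc4ccccc34)nc2n1` gives 191 nM, and compound 3 `Cc1cccc(-c2cc(O)c3c(C)cc(C)nc3n2)c1` gives 20000 nM. Compound 2 and compound 3 have different cores, and the difference between the two cores is not broken down here. Compound 1 and compound 3 differ in one place only, where (hydrogen in place of methyl on an aromatic carbon); this change gives a 620-fold lower number from compound 3 to compound 1 (2.79 log units; beyond the scatter).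

Compound 4 `Cc1ccc2c(O)cc(-c3cccc4ccccc34)nc2n1` has not yet been tested in this assay. It is made from compound 2 by the same change, where (hydrogen in place of methyl on an aromatic carbon); the surroundings of the place are described in the same words for both pairs. Because the step of a 620-fold lower number from compound 3 to compound 1 (2.79 log units; beyond the scatter) is very large, a strong drop in the number is expected here too, though the cores of compound 2 and compound 3 are not the same and the size need not carry over exactly. For compound 4 a step of a 64-fold lower number from compound 2 to compound 4 (1.80 log units; beyond the scatter) is expected in this assay. For compound 4 the estimated value in this assay is 3 nM, with a likely range from 0.5 nM to 30 nM.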

Compound 4, concentration for 50% growth inhibition: < 10 nM
Compound 4 was reported as a limit (the forecaster's own chance of this, stated with the estimate: 5%); the middle value does not contradict the limit.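

In this assay, hydrogen in place of methyl on an aromatic carbon, opposite the ring nitrogen, gives an at least 19-fold lower number from compound 2 to compound 4 (1.28 log units; beyond the scatter), so the number falls on both cores shown. Compound 4 is reported only as a limit, < 10 nM, and not as an exact number. The direction of the change therefore holds across these two pairs, which is useful but thin support for carrying it to a new core, and the limit means the data do not show whether the size of the step carries over as well: the same change on two cores in this assay, a 620-fold lower number (2.79 log units; beyond the scatter) from compound 3 to compound 1 and an at least 19-fold lower number (1.28 log units; beyond the scatter) from compound 2 to compound 4; the limit leaves it open whether they differ

The compounds shown have only methyl or hydrogen at this place, so it remains open how a larger or different group, such as an ethyl group, a chlorine atom or a methoxy group, would behave there. From the compounds shown here alone, it also remains open whether the same step would appear on other cores, for example one carrying an amine or a carboxylic acid.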